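The source may report more compounds than this note shows. Statements on the series, on what has been measured and on what is new or still open speak of the compounds shown alone.

Measured compounds:
Compound 1 `COc1cc2c(Oc3ccc(NC(=O)c4nn(-c5ccccc5)c(=O)cc4C)cc3F)ccnc2cc1OCCCN1CCCC1` gives 220 nM.
Compound 2 `COc1cc2c(Oc3ccc(NC(=O)c4nn(-c5ccccc5)c(=O)cc4C)cc3F)ccnc2cc1OCCCN1CCCCC1` gives 160 nM.
Compound 3 `COc1cc2c(Oc3ccc(NC(=O)c4nn(-c5cccc(F)c5)c(=O)cc4C)cc3F)ccnc2cc1OCCCN1CCCC1` gives 250 nM.

All three compounds were tested in a functional assay on HT-29 cells (Homo sapiens) for inhibition, read by MTT assay, with a stated time of 72 h; a higher number here means a weaker inhibitor, a lower number a stronger inhibitor. Compound 2 is derived from compound 1 by a single change, (piperidin-1-yl in place of pyrrolidin-1-yl on a saturated chain carbon, three bonds along the chain from an oxygen on an aromatic ring), and this gave a 1.4-fold lower number from compound 1 to compound 2 (0.14 log units; within the scatter). The second change from compound 1 leads to compound 3: fluoro in place of hydrogen on an aromatic carbon, which gave a 1.1-fold higher number from compound 1 to compound 3 (0.06 log units; within the scatter). Compound 3 stands at the highest of the three numbers, but its distances to compound 1 and to compound 2 both lie within the scatter, so no order among the three can be read from these data.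

Compound 4 `COc1cc2c(Oc3ccc(NC(=O)c4nn(-c5cccc(F)c5)c(=O)cc4C)cc3F)ccnc2cc1OCCCN1CCCCC1` has not yet been measured in this assay. It differs from compound 3 by piperidin-1-yl in place of pyrrolidin-1-yl on a saturated chain carbon, three bonds along the chain from an oxygen on an aromatic ring. This is the same change as that from compound 1 to compound 2, made here on the core of compound 3 rather than on the core of compound 1; the two cores differ by fluoro in place of hydrogen on an aromatic carbon, and the place of the change is described in identical words in both pairs.

Because a 1.4-fold lower number from compound 1 to compound 2 (0.14 log units; within the scatter) was seen when this change was made once before, compound 4 is expected to show a step of similar size, a 1.4-fold lower number from compound 3 to compound 4 (0.14 log units; within the scatter). For the measured compounds named here, the estimate for compound 4 in this assay is therefore 180 nM, with a range from 90 nM to 360 nM, resting only on the single earlier step and the value of compound 3, 250 nM.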

Compound 4, half-maximal inhibitory concentration: 290 nM
The estimate for compound 4 lay 1.6-fold (0.21 log units) below the measured number; low and high end bracket the measured number.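

On the core bearing the fluoro group in this assay, piperidin-1-yl in place of pyrrolidin-1-yl gave a 1.2-fold higher number from compound 3 to compound 4 (0.06 log units; within the scatter), and this step does not differ from the earlier one on the other core beyond what repeated measurement allows: the same change on two cores in this assay, a 1.4-fold lower number (0.14 log units; within the scatter) from compound 1 to compound 2 and a 1.2-fold higher number (0.06 log units; within the scatter) from compound 3 to compound 4, 1.6-fold (0.20 log units) apart, within the scatter of two such steps. Fluoro in place of hydrogen on an aromatic carbon, read this time with piperidin-1-yl on the chain, gave a 1.8-fold higher number from compound 2 to compound 4 (0.26 log units; within the scatter), and it agrees in the same way with its earlier counterpart: the same change on two cores in this assay, a 1.1-fold higher number (0.06 log units; within the scatter) from compound 1 to compound 3 and a 1.8-fold higher number (0.26 log units; within the scatter) from compound 2 to compound 4, 1.6-fold (0.20 log units) apart, within the scatter of two such steps. The four compounds therefore show that each change stayed within the scatter on both cores, which fits with a step carrying over from one core to the other, but the steps are so small that they do not show that either change has a real effect of its own, or that the two changes add up or interact.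

Still open, from the compounds shown here alone, is how a step would carry over if it were large enough to stand clear of the scatter, for instance with morpholine or a dimethylamino group at the end of the chain, or with a longer chain than 3-(piperidin-1-yl)propyl. Going by these compounds, a chloro or methoxy group in place of the fluoro also remains open, as does the behaviour of all these pairs in cells other than those of this assay.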